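The source may hold more compounds than are shown below. What is called first, only, known or untested is meant among the compounds shown, and "the series" means these compounds.

Going by the values given here, compound 3 `CCCn1cc(CN2CCN(c3cccc4[nH]c(-c5ccc(C(C)(C)C)cc5)nc34)CC2)nc1C` gives the lowest number of the three compounds measured so far in an assay on isolated protein for displacement of a labelled ligand from Gonadotropin-releasing hormone receptor (Rattus norvegicus); on this read-out lower numbers stand for stronger inhibition and higher numbers for weaker inhibition: compound 3 gives 41 nM, compound 2 `CCc1nc(CN2CCN(c3cccc4[nH]c(-c5ccc(C(C)(C)C)cc5)nc34)CC2)cn1C` gives 78 nM, and compound 1 `CCc1nc(C)c(CN2CCN(c3cccc4[nH]c(-c5ccc(C(C)(C)C)cc5)nc34)CC2)o1` gives 320 nM. The step of a 7.8-fold lower number from compound 1 to compound 3 (0.89 log units; beyond the scatter) and the step of a 4.1-fold lower number from compound 1 to compound 2 (0.61 log units; beyond the scatter) both lie beyond the scatter, whereas the step of a 1.9-fold lower number from compound 2 to compound 3 (0.28 log units; within the scatter) does not, so compound 2 and compound 3 cannot be ranked against each other.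

Compound 4 `CCCn1c(CC)nc(C)c1CN1CCN(c2cccc3[nH]c(-c4ccc(C(C)(C)C)cc4)nc23)CC1` differs from compound 3 in one place: 2-ethyl-4-methyl-1-propyl-1H-imidazol-5-yl in place of 2-methyl-1-propyl-1H-imidazol-4-yl on a saturated chain carbon bound to an amine nitrogen in a ring. The imidazole ring is kept, but it now carries an ethyl group and a methyl group, and the attachment point on the ring moves. The measured steps bear on this only in part. They show that exchanging the oxazole of compound 1 for an imidazole gave a modest gain, and that changing the substituents on the imidazole between compound 2 and compound 3 gave a step within the scatter. Among the compounds with values here, no measured pair changes both the substitution and the attachment point of the imidazole, so the expectation rests on the imidazole analogues staying close together. Compound 4 is therefore expected to give a number near that of compound 3, with an expected step of a 1.4-fold lower number from compound 3 to compound 4 (0.14 log units; within the scatter), estimated at 30 nM within a range of 9 nM to 100 nM.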

Compound 4, half-maximal inhibitory concentration: 120 nM
Compound 4: middle estimate off by 4.0-fold (0.60 log units), on the low side; the measured number lies above the stated range.
By their numbers in this assay, from the lowest: compounds 3, 2 and 4 (each within the scatter of the next, the first and the last beyond it); then compound 1.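

Moving to the 2-ethyl-4-methyl-1-propyl-1H-imidazol-5-yl group shows that keeping an imidazole on this saturated chain carbon does not by itself hold the number steady: the change gives a 2.9-fold higher number from compound 3 to compound 4 (0.47 log units; beyond the scatter), the first step beyond the scatter between two imidazole compounds. Against the 2-ethyl-1-methyl-1H-imidazol-4-yl group, the same change gives a 1.5-fold higher number from compound 2 to compound 4 (0.19 log units; within the scatter), so those two compounds cannot be ranked, while against the 2-ethyl-4-methyl-1,3-oxazol-5-yl group it still gives a 2.7-fold lower number from compound 1 to compound 4 (0.43 log units; beyond the scatter), so even this less favourable imidazole keeps a gain over the oxazole. Nothing measured here accounts for these differences.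

The ethyl group, the extra methyl group and the attachment point all change together, so the compounds shown do not tell which of them carries the rise; a 2-ethyl-1-propyl-1H-imidazol-4-yl group would keep the attachment point of compound 3 while adding only the ethyl group. Going by these compounds, how a butyl group in place of the propyl group on the imidazole would behave also remains open.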